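Aryl swap on the triazinedione amide of a bipyridyl ether

A few compounds are considered here, and "the series" means these few. Any claim that something is new, unique, unknown or untested is made for them only; others in the source may bear on it.

Measured compounds:
compound 1 `Fc1ccc(Nc2cc(Nc3ccc(Oc4ccncc4-c4cccnc4)c(F)c3)ncn2)cc1` — 160 nM
compound 2 `Cn1c(=O)c(C(=O)Nc2ccc(Oc3ccncc3-c3cccnc3)c(F)c2)nn(-c2cccc(C(F)(F)F)c2)c1=O` — 1950 nM

Two compounds share the fluorophenoxy-pyridine with a pyridyl on it and differ in the part that carries the anilide. In a functional assay on MKN-45 cells (Homo sapiens) for cytotoxicity, read by MTT assay, with a stated time of 72 h (on this read-out higher numbers stand for weaker inhibition and lower numbers for stronger inhibition), compound 1 gives 160 nM. In this assay compound 2 gives 1950 nM, which is the highest of the two numbers and sits well apart from compound 1, beyond the scatter. Within the data shown here, no step between two measured compounds that differ in only one place is available, so there is no reference for how a change on the triazinedione aryl affects the read-out.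

Compound 3 `COc1ccc(-n2nc(C(=O)Nc3ccc(Oc4ccncc4-c4cccnc4)c(F)c3)c(=O)n(C)c2=O)c(OC)c1` is not yet measured. It differs from compound 2 by 2,4-dimethoxyphenyl in place of 3-(trifluoromethyl)phenyl on an aromatic nitrogen. On these data alone, without a measured one-place step, the size of the step is unknown; on the structural change alone, no step beyond the scatter is expected in either direction. For compound 3 the value in this assay is estimated at 1500 nM, with a range from 400 nM to 6000 nM. This estimate means a step of a 1.3-fold lower number from compound 2 to compound 3 (0.11 log units; within the scatter), which is expected to stay within the scatter.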

Compound 3, half-maximal inhibitory concentration: 2820 nM
Compound 3: the middle estimate sits 1.9-fold (0.27 log units) below what was measured; the measured number falls inside the stated range.
By their numbers in this assay, from the lowest: compound 1; then compounds 2 and 3 (each within the scatter of the next).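

In this assay, the series now has its first one-place reading: 2,4-dimethoxyphenyl in place of 3-(trifluoromethyl)phenyl on the aromatic nitrogen gives a 1.4-fold higher number from compound 2 to compound 3 (0.16 log units; within the scatter) and so marks no measurable difference between these two aryl groups. The exchange replaces a trifluoromethyl substituent with two methoxy groups and brings in 2 hydrogen-bond acceptors where the leaving group has none, yet compound 2 and compound 3 remain within the scatter of each other on this read-out. No measured evidence offers an explanation for this result.

On these data alone, only these two aryl groups have been compared at this position, so it remains open whether an unsubstituted phenyl, a group bearing an amine or a carboxylic acid, or a simple alkyl chain on the same nitrogen would move the number beyond the scatter. Compound 1, at 160 nM, differs from compound 2 and compound 3 in more than one place, so its value cannot be tied to this position or to any single part of the structure.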